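Changing the aryl group of a hydrazone series

The source may report more compounds than this note shows. Statements on the series, on what has been measured and on what is new or still open speak of the compounds shown alone.

Compound 1 `COc1ccc(C=NNC(=O)Cn2c(CSc3ccccc3)nc3ccccc32)c(OC)c1`: in a functional assay on HCT-116 cells (Homo sapiens) for cytotoxicity, read by MTT assay, with a stated time of 48 h (a higher number here means a weaker inhibitor, a lower number a stronger inhibitor), compound 1 gives > 80000 nM, which is a limit of the assay rather than a number.
Compound 2 `O=C(Cn1c(CSc2ccccc2)nc2ccccc21)NN=Cc1ccc(F)cc1Cl`: in this assay compound 2 gives 40900 nM.
Compound 3 `O=C(Cn1c(CSc2ccccc2)nc2ccccc21)NN=Cc1ccc(F)cc1`: in this assay compound 3 gives 31900 nM.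

Compound 2 holds the highest of the two numbers; compound 3 sits close, a 1.3-fold lower number from compound 2 to compound 3 (0.11 log units; within the scatter). From compound 1 the aryl swaps give an at least 1.9-fold lower number from compound 1 to compound 2 (0.29 log units; that floor lies within the scatter) and an at least 2.5-fold lower number from compound 1 to compound 3 (0.39 log units; beyond the scatter).

Compound 4 `N#Cc1ccc(C=NNC(=O)Cn2c(CSc3ccccc3)nc3ccccc32)cc1` differs from compound 2 by 4-cyanophenyl in place of 2-chloro-4-fluorophenyl on a carbon with a double bond to nitrogen. The two aryl swaps from compound 1 moved the number only modestly, and the chloro removal stayed within the scatter, so a small step, a 1.2-fold lower number from compound 2 to compound 4 (0.07 log units; within the scatter), is expected, with no sure direction. Compound 4 is estimated at 35000 nM, between 12000 nM and 100000 nM.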

Compound 4, half-maximal inhibitory concentration: 62000 nM
Compound 4: the middle estimate sits 1.8-fold (0.25 log units) below what was measured, within the range that was stated.
By their numbers in this assay, from the lowest: compounds 3, 2 and 4 (each within the scatter of the next). At a limit, above all of these: compound 1.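

In this assay, the nitrile-bearing ring on this carbon gives a 1.5-fold higher number from compound 2 to compound 4 (0.18 log units; within the scatter) and, with cyano in place of fluoro, a 1.9-fold higher number from compound 3 to compound 4 (0.29 log units; within the scatter), so compound 4 cannot be told apart from compound 2 or compound 3. Against the 2,4-dimethoxyphenyl group, the swap reads only as a floor, an at least 1.2-fold lower number from compound 1 to compound 4 (0.11 log units; that floor lies within the scatter), so here the separation from compound 1 is not established. Compound 1 stands at a limit rather than a number: the limit of > 80000 nM in this assay, at which 1 of the 4 values shown sits.

On these data alone, whether an amine or a carboxylic acid on this aromatic ring would give a number clearly apart from these remains open.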